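Oxazole series: carbamoyl to fluoro at the ring carbon

The compounds below may be only part of what the source reports. "The series", "measured", "known", "first", "only" and "open" are said of these compounds alone.

Compound 1 `O=C(O)c1ccc(-c2cnc(C(=O)CCCCCCc3ccccc3)o2)cc1` gives 60 nM in an assay (Rattus norvegicus) for inhibition of Fatty-acid amide hydrolase 1 (Homo sapiens); a lower number here means a stronger inhibitor, a higher number a weaker inhibitor.
Compound 2 `COc1ccc(-c2cnc(C(=O)CCCCCCc3ccccc3)o2)cc1` gives 100 nM in this assay.
Compound 3 `CN(C)C(=O)c1cnc(C(=O)CCCCCCc2ccccc2)o1` gives 2 nM in this assay.

Compound 3 stands lowest of the three; the steps of a 30-fold lower number from compound 1 to compound 3 (1.48 log units; beyond the scatter) and a 50-fold lower number from compound 2 to compound 3 (1.70 log units; beyond the scatter) are both large, while a 1.7-fold higher number from compound 1 to compound 2 (0.22 log units; within the scatter) is within the scatter.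

Compound 4 `O=C(CCCCCCc1ccccc1)c1ncc(F)o1` carries the change (fluoro in place of dimethylcarbamoyl on an aromatic carbon). For the measured compounds named here, no measured step covers this exchange: the two large steps both concern dimethylcarbamoyl entering in place of an aryl group, and fluoro resembles neither. The number for compound 4 is therefore expected to rise beyond the scatter from compound 3, with wide uncertainty, as a 20-fold higher number from compound 3 to compound 4 (1.30 log units; beyond the scatter). The estimate for compound 4 in this assay is 40 nM, between 8 nM and 200 nM.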

Compound 4, inhibition constant: 30 nM
Compound 4: middle estimate off by 1.3-fold (0.12 log units), on the high side, within the range that was stated.
By their numbers in this assay, from the lowest: compound 3; then compounds 4, 1 and 2 (each within the scatter of the next, the first and the last beyond it).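

On the aromatic carbon next to the ring oxygen, fluoro does not match dimethylcarbamoyl in this assay (a 15-fold higher number from compound 3 to compound 4 (1.18 log units; beyond the scatter)). Fluoro also differs by a modest step from the 4-methoxyphenyl group (a 3.3-fold lower number from compound 2 to compound 4 (0.52 log units; beyond the scatter)), but it cannot be told apart from the 4-carboxyphenyl group (a 2.0-fold lower number from compound 1 to compound 4 (0.30 log units; within the scatter)), so an aryl group is not required for numbers in this range. No evidence on the source of these differences is available.

As far as these compounds go, it remains open whether the advantage of compound 3 rests on the carbonyl or on the two methyl groups of its amide. An unsubstituted carboxamide, a methyl ester or a nitrile on this carbon would separate those parts.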